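A 3,5-dimethoxyphenyl group replaces phenyl in compound 2

The source may hold more compounds than are shown below. What is called first, only, known or untested is meant among the compounds shown, and "the series" means these compounds.

Compound 1 (`COc1ccc(S(=O)(=O)c2nc3ccccc3nc2Nc2cc(OC)cc(OC)c2)cc1`) gives 1710 nM
Compound 2 (`O=S(=O)(c1ccc(Br)cc1)c1nc2ccccc2nc1Nc1ccccc1`) gives 130 nM

Both compounds were tested in a functional assay on HL-60 cells (Homo sapiens) for cytotoxicity, read by MTT assay, with a stated time of 72 h (on this read-out lower numbers stand for stronger inhibition and higher numbers for weaker inhibition), and their numbers lie well apart. Compound 2 (130 nM) holds the lower of the two numbers, and its gap to compound 1 lies beyond the scatter.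

Compound 3 (`COc1cc(Nc2nc3ccccc3nc2S(=O)(=O)c2ccc(Br)cc2)cc(OC)c1`) has not yet been measured in this assay and departs from compound 2 in one place: 3,5-dimethoxyphenyl in place of phenyl on a nitrogen on an aromatic ring. The 3,5-dimethoxyphenyl group therefore takes the place of phenyl on a nitrogen on an aromatic ring, while the rest of compound 2 stays unchanged.

Among the measured compounds shown here, the only measured guide to this group is compound 1 (1710 nM), which carries it on the same nitrogen. Compound 1 also differs from compound 2 elsewhere, so the data do not isolate the effect of this one change. What is expected is a 3.5-fold higher number from compound 2 to compound 3 (0.54 log units; beyond the scatter) in the direction of weaker inhibition, a moderate step beyond the scatter. Compound 3 is estimated at 450 nM (expected range 130 nM to 1500 nM).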

Compound 3, half-maximal inhibitory concentration: 2540 nM
The estimate for compound 3 lay 5.6-fold (0.75 log units) below the measured number; the measured number lies above the stated range.
By their numbers in this assay, from the lowest: compound 2; then compounds 1 and 3 (each within the scatter of the next).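

In this assay, putting 3,5-dimethoxyphenyl in place of phenyl on the nitrogen, with the rest of compound 2 unchanged, gives a 20-fold higher number from compound 2 to compound 3 (1.29 log units; beyond the scatter), so this single change is now seen on its own as a large step towards weaker inhibition, which the earlier pair could not show. With 3,5-dimethoxyphenyl held on that nitrogen, bromo in place of methoxy on an aromatic carbon gives a 1.5-fold higher number from compound 1 to compound 3 (0.17 log units; within the scatter), which lies within the scatter, so this exchange shows no readable difference in that setting. No measurement at hand offers a reason for the large step at the nitrogen.

The compounds shown leave open whether the exchange of bromo and methoxy would stay just as silent with plain phenyl on the nitrogen. They also leave open how much of the step a single methoxy on the phenyl ring would reproduce, and how a phenyl ring bearing a hydroxy group or an amine at that nitrogen would read in this assay.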